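Chain-End Amide to Sulfonamide: Cytotoxicity Outlook

The source may hold more compounds than are shown below. What is called first, only, known or untested is meant among the compounds shown, and "the series" means these compounds.

Compound 1 `Cc1ccc(S(=O)(=O)N[C@@H](CC(=O)NC(C)(C)C)C(=O)NCCNC(=O)c2ccccc2)cc1` gives > 11000 nM in an ADME assay on HepG2 cells (Homo sapiens) for cytotoxicity (on this read-out higher numbers stand for an effect only at larger amounts of compound and lower numbers for an effect already at smaller amounts), a limit of the assay. Compound 2 `Cc1ccc(S(=O)(=O)N[C@@H](CC(=O)NC(C)(C)C)C(=O)NCCNC(=O)c2ccccc2F)cc1` gives > 11000 nM in this assay, again a limit. Compound 3 `Cc1ccc(S(=O)(=O)N[C@@H](CC(=O)NC(C)(C)C)C(=O)NCCNC(=O)c2ccc(F)cc2)cc1` gives > 11000 nM in this assay, also a limit.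

All three measured compounds therefore stand at the limit of > 11000 nM in this assay, at which 3 of the 3 values shown sit, so compound 2 sits exactly where its two neighbours sit, and no number separates any of them. The measured steps are a step that the two limits leave unreadable from compound 1 to compound 2, a step that the two limits leave unreadable from compound 1 to compound 3 and a step that the two limits leave unreadable from compound 2 to compound 3; each of them is unreadable because the limit of > 11000 nM in this assay, at which 3 of the 3 values shown sit, caps both ends.

Compound 4 `Cc1ccc(S(=O)(=O)N[C@@H](CC(=O)NC(C)(C)C)C(=O)NCCNS(=O)(=O)c2ccccc2)cc1` differs from compound 2 by phenylsulfonyl in place of (2-fluorophenyl)carbonyl on an amine nitrogen. Among the measured compounds shown here, none of the measured steps touches a phenylsulfonyl group, so none bears directly on this change, and the unreadable steps between compounds 1, 2 and 3 give no size at all. What the series does show is that varying the terminal aromatic acyl group left every compound at the limit. Compound 4 is therefore expected to give 20000 nM, with a range from 8000 nM to 60000 nM. The expected step is a step that the limit leaves unreadable from compound 2 to compound 4, meaning no change beyond the scatter, most likely another limit rather than a number.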

Compound 4, half-maximal effective concentration: > 11000 nM
Compound 4 ended at the assay's limit; the forecaster's own chance of this, stated with the estimate: 85%; the middle value does not contradict the limit.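

In this assay compound 4 gives > 11000 nM as a limit of the assay. No step from compound 1, compound 2 or compound 3 to compound 4 can be read, because each end of these steps is capped: the limit of > 11000 nM in this assay, at which 4 of the 4 values shown sit.

The compounds shown leave open whether compound 4 truly differs from compound 1, compound 2 or compound 3 on this read-out, and at what concentration any of them would show an effect.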